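A few compounds are considered here, and "the series" means these few. Any claim that something is new, unique, unknown or untested is made for them only; others in the source may bear on it.

For the measured compounds named here, in an ADME assay on L6 cells (Rattus norvegicus) for cytotoxicity, read by fluorescence and resazurin assay, with a stated time of 72 h (a lower number here means that less compound is needed, a higher number that more compound is needed for the effect), three compounds have numbers so far.

Compound 1, `O=c1nc(-c2ccccc2)c2cc(-c3ccccc3F)ccc2[nH]1`, gives 55800 nM.
Compound 2, `N#Cc1ccc(-c2ccc3[nH]c(=O)nc(-c4ccccc4)c3c2)cc1`, reaches only the limit of the method, > 50000 nM.
Compound 3, `Cn1nccc1-c1ccc2[nH]c(=O)nc(-c3ccccc3)c2c1`, likewise reaches only the limit, > 50000 nM.

So compound 3 stands at a limit rather than at a number, and the same is true of compound 2; compound 1 is the only one of the three with a readable number, and that number is itself high. The steps that lead to compound 3 cannot be sized: a step that the limit leaves unreadable from compound 1 to compound 3 and a step that the two limits leave unreadable from compound 2 to compound 3, both because of the limit of > 50000 nM in this assay, at which 2 of the 3 values shown sit.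

Compound 4, `CN1CCN(c2ccc3[nH]c(=O)nc(-c4ccccc4)c3c2)CC1`, differs from compound 3 in one place: 4-methylpiperazin-1-yl in place of 1-methyl-1H-pyrazol-5-yl on an aromatic carbon. Going by the values given here, none of the measured steps involves a 4-methylpiperazin-1-yl group, and every step that touches compound 3 is unreadable, so there is no measured step whose size can be carried over to this change. What the three values do show is that swapping the group on this aromatic carbon has so far moved nothing out of the high range. Compound 4 is therefore expected to stay near the limit, with the step of a number no higher from compound 3 to compound 4 (the limit leaves the size open) estimated to be about nothing beyond the scatter. The estimate for compound 4 in this assay is 50000 nM, within a range of 20000 nM to 100000 nM.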

Compound 4, half-maximal effective concentration: > 50000 nM
Compound 4 gave a limit, no number; the forecaster's own chance of this, stated with the estimate: 60%; the middle value lies on the limit itself.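

Compound 4 gives only a limit, so no step from compound 1, compound 2 or compound 3 to compound 4 can be sized, because of this: the limit of > 50000 nM in this assay, at which 3 of the 4 values shown sit.

The compounds shown leave open how compound 2, compound 3 and compound 4 rank against each other in this assay, and whether any group on this aromatic carbon gives a number well inside the assay's range.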